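The source may hold more compounds than are shown below. What is called first, only, known or untested is meant among the compounds shown, and "the series" means these compounds.

Among the measured compounds shown here, in a functional assay on KYSE-70 cells for antiproliferative activity against KYSE-70 cell line (Homo sapiens), read by MTT assay, with a stated time of 72 h (on this read-out lower numbers stand for stronger inhibition and higher numbers for weaker inhibition), compound 2 `O=C(Nc1cccc(F)c1)c1cc(=O)[nH]c2cc(-c3ccsc3)ccc12` gives 5100 nM, the only numeric reading so far. Compound 1 `COc1ccc(-c2ccc3c(C(=O)Nc4cccc(F)c4)cc(=O)[nH]c3c2)cc1` stands at > 20000 nM, which is a limit of the assay and not a number. Compound 3 `Cc1ccc(-c2ccc3c(C(=O)Nc4cccc(F)c4)cc(=O)[nH]c3c2)cc1` differs from compound 2 in one place: 4-methylphenyl in place of thiophen-3-yl on an aromatic carbon. The entering 4-methylphenyl is a six-membered aromatic ring of carbon only, and so is the 4-methoxyphenyl of compound 1. For the measured compounds named here, one measured step bears on this change: an at least 3.9-fold lower number from compound 1 to compound 2 (0.59 log units; beyond the scatter). That step is beyond the scatter, but its size is only a bound, and the present change runs roughly the opposite way. A move to a higher number in this assay is therefore expected, of modest size or more, and it may reach the limit. The expected step is a 2.7-fold higher number from compound 2 to compound 3 (0.44 log units; beyond the scatter). For compound 3 the estimated value is 14000 nM, with an expected range of 6000 nM to 28000 nM.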

Compound 3, half-maximal inhibitory concentration: > 20000 nM
Compound 3: only a limit was reported; the forecaster's own chance of this, stated with the estimate: 40%; middle value at least 1.4-fold (0.15 log units) away from the limit.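

In this assay, the change at this position on the shared core gives an at least 3.9-fold higher number from compound 2 to compound 3 (0.59 log units; beyond the scatter). The earlier step could not separate the ring from its methoxy group, but compound 3 carries methyl instead of methoxy and still reaches a limit, so the methoxy group is not needed for the weak reading. The step from compound 1 to compound 3 cannot be read, and among the compounds shown only the thiophen-3-yl of compound 2 gives a numeric reading, the rest sitting at a limit: the limit of > 20000 nM in this assay, at which 2 of the 3 values shown sit.

From the compounds shown here alone, whether the higher number follows the six-membered ring itself or its substituent stays open, a question on which an unsubstituted phenyl would bear. Also open, going by these compounds, is whether thiophen-3-yl is special among five-membered rings, or whether furan-3-yl or thiophen-2-yl would read alike.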